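The source may report more compounds than this note shows. Statements on the series, on what has been measured and on what is new or still open speak of the compounds shown alone.

Measured so far, in an assay on HEK293 cells for positive allosteric modulation of metabotropic glutamate receptor 5 (Homo sapiens), read by FLIPR; a higher number here means that more compound is needed for the effect, a lower number that less compound is needed:

- Compound 1 `O=C(N1CCC(F)CC1)N1CC(c2nc(-c3cccc(Cl)c3)no2)C1`: 990 nM
- Compound 2 `Cc1cccc(S(=O)(=O)N2CC(c3nc(-c4cccc(Cl)c4)no3)C2)c1`: > 10000 nM, which is a limit of the assay and not a number

Compound 1 holds the only number shown in this assay; the other value is a limit, (the limit of > 10000 nM in this assay, at which 1 of the 2 values shown sits). Among the compounds with values here, no step between two measured compounds is available, so the pair can only be read as one number and one limit. Nothing further is known about the sulfonamide of compound 2.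

Compound 3 `O=C(C1CCC1)N1CC(c2nc(-c3cccc(Cl)c3)no2)C1` keeps the shared core of compound 1 and alters the group on the carbonyl carbon: cyclobutyl in place of 4-fluoropiperidin-1-yl on a carbonyl carbon. The amide-type nitrogen in the ring remains; the cyclobutyl now sits where the 4-fluoropiperidin-1-yl sat. Within the data shown here, no measured step tells how a change of this kind plays out in this assay, so the expectation rests on compound 1 alone, and the expected step of a 1.5-fold higher number from compound 1 to compound 3 (0.18 log units; within the scatter) is taken as small, toward a little less activity, and possibly within the scatter. Compound 3 is estimated at 1500 nM, within a range of 400 nM to 6000 nM.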

Compound 3, half-maximal effective concentration: > 10000 nM
Compound 3 gave a limit, no number; the forecaster's own chance of this, stated with the estimate: 15%; middle value at least 6.6-fold (0.82 log units) from the limit.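

In this assay compound 3 reads > 10000 nM, which is a limit of the assay and not a number. Within the data shown here, the group on the carbonyl carbon now has its only readable step, an at least 10-fold higher number from compound 1 to compound 3 (1.00 log units; beyond the scatter), so this place is not indifferent to what sits on it, and cyclobutyl in place of 4-fluoropiperidin-1-yl does not keep the activity of compound 1 in this series. As far as these compounds go, the step can be read only as a bound and its full size stays unknown, because the reading of compound 3 sits at the assay limit: the limit of > 10000 nM in this assay, at which 2 of the 3 values shown sit.

The change removes the ring nitrogen on the carbonyl carbon, the fluorine and the six-membered ring all at once, and the compounds shown leave open which of these accounts for the step. Also open, from the compounds shown here alone, is how a piperidin-1-yl without fluorine, a morpholin-4-yl or a cyclohexyl would read on the same carbonyl carbon, and each of these would separate the parts of that single change.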